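The source may hold more compounds than are shown below. What is called first, only, known or untested is meant among the compounds shown, and "the series" means these compounds.

Compound 1 `Brc1ccccc1COc1nc2ccccc2s1` gives 75.6% in a functional assay on the whole organism with Mus musculus as the target, with a stated time of 1 h, at a dose of 100 mg/kg by the intraperitoneal route (on this read-out lower numbers stand for less inhibition and higher numbers for more inhibition at the one dose given (going by the name of the read-out)), and stands highest of the two values in hand. Among the compounds with values here, compound 2 `FC(F)(F)c1ccc(COc2nc3ccccc3s2)cc1` gives 12.2% in this assay, a gap beyond the scatter against compound 1, though no single-site step links the pair. Compound 3 `Clc1ccccc1COc1nc2ccccc2s1` follows from compound 1 by chloro in place of bromo on an aromatic carbon. Within the data shown here, with no measured one-place step to lean on, a step of only modest size is expected, within or at the edge of the scatter, leaning slightly downward: a number 10.6 percentage points lower from compound 1 to compound 3 (beyond the scatter). Compound 3 is thus estimated at 65% in this assay, within 40% to 85%.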

Compound 3, a percentage reported as inhibition, in the whole organism at one dose (the size of the read-out at that dose, not a potency): 14.6%
Estimate against measurement, compound 3: 50.4 percentage points above; measured number outside the range, below it.
By their numbers in this assay, from the lowest: compounds 2 and 3 (each within the scatter of the next); then compound 1.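

In this assay, this position on an aromatic carbon ortho to a large group proves highly sensitive to the identity of the halogen: chloro in place of bromo gives a number 61 percentage points lower from compound 1 to compound 3 (beyond the scatter) and so cannot be treated as a conservative exchange here. Nothing at hand accounts for the size of this step.

From the compounds shown here alone, whether a methyl group, a methoxy group or fluoro at this same place would behave like bromo or like chloro stays open. Also open, going by these compounds, is whether bromo needs this particular place on the ring to go with a high number.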